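Benzyl extension on the shared core: cytotoxicity notes

The compounds below may be only part of what the source reports. "The series", "measured", "known", "first", "only" and "open" are said of these compounds alone.

Measured compounds:
compound 1, `CN1CCN(c2ccc(NC(=N)c3cc4cnn(C)c4cn3)cc2)CC1`: 32300 nM
compound 2, `COc1ccc(Cn2ncc3cc(C(=N)Nc4ccc(N5CCN(C)CC5)cc4)ncc32)cc1`: 6100 nM
compound 3, `Cn1ncc2cc(C(=N)Nc3cccc(C(F)(F)F)c3)ncc21`: 50000 nM

In a functional assay on PC-3 cells (Homo sapiens) for cytotoxicity, read by MTT assay, with a stated time of 72 h (a higher number here means a weaker inhibitor, a lower number a stronger inhibitor), compound 1 gives 32300 nM. The change from compound 1 to compound 2 is 4-methoxyphenyl in place of hydrogen on a saturated chain carbon bound to an aromatic nitrogen. In this assay compound 2 gives 6100 nM, a step of a 5.3-fold lower number from compound 1 to compound 2 (0.72 log units; beyond the scatter). Compound 3 gives 50000 nM in this assay; its value sits within the scatter of compound 1 and beyond the scatter of compound 2. The difference between the core of compound 3 and the core of compound 1 is not broken down here.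

Compound 4, `COc1ccc(Cn2ncc3cc(C(=N)Nc4cccc(C(F)(F)F)c4)ncc32)cc1`, has not yet been measured. It differs from compound 3 by 4-methoxyphenyl in place of hydrogen on a saturated chain carbon bound to an aromatic nitrogen, the same change as from compound 1 to compound 2, made at the same place. Among the measured compounds shown here, compound 4 is expected to move from compound 3 by about a 5.3-fold lower number from compound 3 to compound 4 (0.72 log units; beyond the scatter) in this assay, because the earlier step of a 5.3-fold lower number from compound 1 to compound 2 (0.72 log units; beyond the scatter) is the only guide available. Compound 4 is therefore estimated at 9500 nM in this assay, between 3500 nM and 26000 nM.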

Compound 4, half-maximal inhibitory concentration: 27600 nM
The estimate for compound 4 lay 2.9-fold (0.46 log units) below the measured number, and the stated range ends below it.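

Carried onto the core of compound 3, the change from methyl to 4-methoxybenzyl gives a 1.8-fold lower number from compound 3 to compound 4 (0.26 log units; within the scatter) in this assay, so on this core it leaves the number within the scatter. The size of the step therefore does not transfer between the two cores: the same change on two cores in this assay, a 5.3-fold lower number (0.72 log units; beyond the scatter) from compound 1 to compound 2 and a 1.8-fold lower number (0.26 log units; within the scatter) from compound 3 to compound 4, 2.9-fold (0.47 log units) apart, beyond the scatter of two such steps

This shows that, on these two pairs, the change cannot be treated as a fixed increment in this series; it does not show which part of the cores accounts for the gap, nor how the change would read on any further core.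

Still open, going by these compounds, is whether the larger step belongs to the core of compound 1 alone or would recur on other cores. Also open, on these data alone, is how this assay would respond to other groups at this place on the aromatic nitrogen, such as an unsubstituted benzyl, or a longer chain ending in an amine or a carboxylic acid.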